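Branching the Sulfated Sphingolipid Chain: Methyl Added Near Terminus

The source may hold more compounds than are shown below. What is called first, only, known or untested is meant among the compounds shown, and "the series" means these compounds.

Compound 1 `CCCCCCCCCCC/C=C/C[C@H](OS(=O)(=O)O)[C@H](O)[C@H](N)CO` and compound 2 `CCCCCCCCCC/C=C/C[C@H](OS(=O)(=O)O)[C@H](O)[C@H](N)CO` differ only at the far end of the alkyl chain. In a functional assay on K562 cells (Homo sapiens) for cytotoxicity (on this read-out higher numbers stand for lower toxicity in this test and lower numbers for higher toxicity in this test), compound 1 gives 8000 nM, and compound 2 gives 7000 nM. Compound 2 thus holds the lowest of the two numbers, though its value and that of compound 1 lie within the scatter of each other, as a 1.1-fold lower number from compound 1 to compound 2 (0.06 log units; within the scatter) shows. Compound 3 `CC(C)CCCCCCCC/C=C/C[C@H](OS(=O)(=O)O)[C@H](O)[C@H](N)CO` is not yet measured; it differs from compound 2 by methyl in place of hydrogen on a saturated chain carbon bound to two saturated chain carbons. For the measured compounds named here, the only measured step that bears on this, the step from compound 1 to compound 2, also moved a methyl on a saturated chain carbon far from the double bond and stayed within the scatter. Compound 3 is therefore expected to give a value in this assay close to that of compound 2, with a step of a 1.1-fold higher number from compound 2 to compound 3 (0.03 log units; within the scatter) and no change beyond the scatter. Compound 3 is estimated at 7500 nM, between 3500 nM and 16000 nM.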

Compound 3, concentration lethal to 50% of the cells: 8000 nM
Compound 3: the middle estimate sits 1.1-fold (0.03 log units) below what was measured; the range from low to high includes it.
By their numbers in this assay, from the lowest: compounds 2, 1 and 3 (each within the scatter of the next).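

In this assay, methyl in place of hydrogen on a saturated chain carbon bound to two saturated chain carbons gives a 1.1-fold higher number from compound 2 to compound 3 (0.06 log units; within the scatter), so this first branch in the series leaves the read-out within the scatter. Isopropyl in place of propyl gives no change at the digits printed from compound 1 to compound 3 (within the scatter), which shows that the branched and unbranched chain ends of the same carbon count cannot be told apart in this test, whereas the earlier pair had addressed only a single methyl added to a straight chain. No measurement is at hand that would explain this flat result.

What the compounds shown leave open is whether a chain end carrying a carboxylic acid or an amine would stay within the scatter as well. A much longer chain or a phenyl group at the same end also remains an open case.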